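The compounds below may be only part of what the source reports. "The series", "measured", "known", "first", "only" and "open" are said of these compounds alone.

Working notes on the series in an assay on isolated protein for inhibition of RAC-alpha serine/threonine-protein kinase (Homo sapiens), read by fluorescence, with a stated time of 30 min, tested at 10 uM; on this read-out higher numbers stand for more inhibition at the one concentration tested (going by the name of the read-out) and lower numbers for less inhibition.

Three compounds of the shared core have numbers. Compound 1, `O=C(/C=C/c1ccc([N+](=O)[O-])cc1)Nc1cc(Sc2ncn[nH]2)c(O)c2ccccc12`, gives 40.6% in this assay. Compound 2, `Cc1cccc(C(=O)Nc2cc(Sc3ncn[nH]3)c(O)c3ccccc23)c1`, gives 20.2%. Compound 3, `O=C(Nc1cc(Sc2ncnc3nc[nH]c23)c(O)c2ccccc12)c1ccc(Cl)cc1`, gives 21.7%. Compound 1 stands highest of the three; the nearest of the others is compound 3, whose value lies lower by a gap beyond the scatter, and the furthest is compound 2, also lower by a gap beyond the scatter. The two benzamides, compound 2 and compound 3, sit within the scatter of one another.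

The step under study goes from compound 1 to compound 4, `COc1ccc(/C=C/C(=O)Nc2cc(Sc3ncn[nH]3)c(O)c3ccccc23)cc1OC`, which is not yet measured in this assay. The change is 3,4-dimethoxyphenyl in place of 4-nitrophenyl on a double-bonded chain carbon bound to a double-bonded chain carbon. Among the measured compounds shown here, no measured pair in this set shows this change, so the direction and size rest only on the structures and the numbers above. Since compound 4 keeps the chain of compound 1 while the ring substituents are exchanged, the value is expected to stay in the upper part of the range, with a modest downward step expected, a number 10.6 percentage points lower from compound 1 to compound 4 (beyond the scatter), roughly at the edge of the scatter. Compound 4 is therefore estimated at 30%, with a range from 12% to 48%.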

Compound 4, a percentage reported as inhibition, at one concentration (the size of the read-out at that concentration, not a potency): 31.7%
For compound 4 the middle estimate is 1.7 percentage points below the measured one, within the range that was stated.
By their numbers in this assay, from the lowest: compounds 2, 3, 4 and 1 (each within the scatter of the next, the first and the last beyond it).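

In this assay, among the compounds shown here, 3,4-dimethoxyphenyl in place of 4-nitrophenyl on a double-bonded chain carbon bound to a double-bonded chain carbon gives a number 8.9 percentage points lower from compound 1 to compound 4 (within the scatter) and is the first one-place comparison. At this position, therefore, the read-out does not separate the two rings, and the nitro group is not needed to keep the number within the scatter of that of compound 1 in this single pair. No measurement on hand bears on the reason for this result.

On these data alone, whether an unsubstituted phenyl, a single methoxy group, or a ring carrying an amine or a carboxylic acid would read alike at this position remains open. Also open, as far as these compounds go, is how a longer chain in place of the double-bonded chain would read on the same ring.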